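The source may report more compounds than this note shows. Statements on the series, on what has been measured and on what is new or still open speak of the compounds shown alone.

Compound 1 `Cn1cc(-c2ccccc2Oc2ccccc2)c2cc(C(=O)NCCCCCCC(=O)NO)[nH]c2c1=O` inhibits an assay on isolated protein for inhibition of protein deacetylase HDAC6 (Homo sapiens), read by fluorescence (on this read-out higher numbers stand for weaker inhibition and lower numbers for stronger inhibition), with 4.7 nM. Among the three compounds measured in this assay it has the second highest number. Compound 3 `O=C(CCCCCCC(=O)Nc1cnc(N(c2ccccc2)c2ccccc2)nc1)NO` gives 4.4 nM, a difference from compound 1 that lies within the scatter, so the two cannot be ranked. Compound 2 `Cc1cc(F)cc(C)c1Oc1ccc(C(C)(C)O)cc1-c1cn(C)c(=O)c2[nH]c(C(=O)NCCCCCCC(=O)NO)cc12` gives 17.2 nM, a gap beyond the scatter, so compound 2 is the weaker inhibitor of that pair.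

Compound 4 `Cn1cc(-c2ccccc2Oc2ccccc2)c2cc(C(=O)NCCCCCC(=O)Nc3ccccc3N)[nH]c2c1=O` differs from compound 1 in one place: (2-aminophenyl)carbamoyl in place of (hydroxycarbamoyl)methyl on a saturated chain carbon, five bonds along the chain from an amide-type nitrogen. Among the measured compounds shown here, no measured pair shows this change, so its effect is not known from these data. A large step toward weaker inhibition, well beyond the scatter, is expected in this assay from compound 1 to compound 4, as a 320-fold higher number from compound 1 to compound 4 (2.50 log units; beyond the scatter). Compound 4 is therefore expected to give about 1500 nM, with a range from 300 nM to 10000 nM.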

Compound 4, half-maximal inhibitory concentration: > 500 nM
Compound 4 was reported as a limit; the forecaster's own chance of this, stated with the estimate: 25%; the middle value does not contradict the limit.
By their numbers in this assay, from the lowest: compounds 3 and 1 (each within the scatter of the next); then compound 2. At a limit, above all of these: compound 4.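

Replacing (hydroxycarbamoyl)methyl with (2-aminophenyl)carbamoyl on the saturated chain gives an at least 100-fold higher number from compound 1 to compound 4 (2.02 log units; beyond the scatter) in this assay, the first one-place change among these compounds. Among the compounds shown here, it shows that inhibition here depends heavily on the group at this chain end, which the earlier compounds could not show because all of them carry the hydroxycarbamoyl end. Compound 4 is reported only as a limit: the limit of > 500 nM in this assay, at which 1 of the 4 values shown sits.

As far as these compounds go, whether a carboxylic acid at this chain end would keep any inhibition stays open. So does whether a longer chain would change the result for the (2-aminophenyl)carbamoyl group.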